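Where compound 3 may land after compound 2

The source may report more compounds than this note shows. Statements on the series, on what has been measured and on what is new or still open speak of the compounds shown alone.

Compound 1 `COc1ccc(C(=O)/C=C/c2ccc(N(C)C)cc2)c2c1C=CC(C)(C)O2`: 1870 nM
Compound 2 `COc1ccc(C(=O)/C=C/c2ccc(Cl)c(Cl)c2)c2c1C=CC(C)(C)O2`: 7580 nM

Going by the values given here, in a functional assay on HT-29 cells (Homo sapiens) for antiproliferative activity, read by MTT assay, with a stated time of 24 h (on this read-out higher numbers stand for weaker inhibition and lower numbers for stronger inhibition), compound 2 gives 7580 nM, the higher of the two numbers so far, which makes it the weaker inhibitor of the pair. Compound 3 `COc1ccc(C(=O)/C=C/c2cc(Cl)ccc2O)c2c1C=CC(C)(C)O2` has not been measured yet. It differs from compound 2 in one place, on a double-bonded chain carbon bound to a double-bonded chain carbon, where 5-chloro-2-hydroxyphenyl stands in place of 3,4-dichlorophenyl: 5-chloro-2-hydroxyphenyl in place of 3,4-dichlorophenyl on a double-bonded chain carbon bound to a double-bonded chain carbon.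

Among the compounds with values here, only one measured step touches this place: a 4.1-fold higher number from compound 1 to compound 2 (0.61 log units; beyond the scatter). That modest step shows that a change here can move the number. Neither measured compound carries the 5-chloro-2-hydroxyphenyl group, so the direction remains uncertain. Compound 2, at 7580 nM, sits at the top of just two numbers, so a lower number seems the likelier outcome. The expected step in this assay is a 1.9-fold lower number from compound 2 to compound 3 (0.28 log units; within the scatter), which is smaller than the measured one. For compound 3 the estimate is 4000 nM, with an expected range from 1300 nM to 12000 nM.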

Compound 3, half-maximal inhibitory concentration: 4970 nM
Estimate against measurement, compound 3: 1.2-fold (0.09 log units) below; measured number inside the range.
By their numbers in this assay, from the lowest: compound 1; then compounds 3 and 2 (each within the scatter of the next).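

In this assay, putting 5-chloro-2-hydroxyphenyl in place of 3,4-dichlorophenyl on a double-bonded chain carbon bound to a double-bonded chain carbon gives a 1.5-fold lower number from compound 2 to compound 3 (0.18 log units; within the scatter), so this exchange, which brings in a hydrogen-bond donor and a hydrogen-bond acceptor and leaves one chlorine instead of two, does not clearly separate the two compounds. Measured against the 4-(dimethylamino)phenyl group, the same new group gives a 2.7-fold higher number from compound 1 to compound 3 (0.42 log units; beyond the scatter), which makes compound 1 the strongest inhibitor of the three, since its steps to both of the others lie beyond the scatter. The earlier step rested on a single chlorinated ring, whereas two differently substituted chlorinated rings now both give clearly higher numbers than compound 1, so the gap from compound 1 no longer hangs on the 3,4-dichlorophenyl group alone.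

On these data alone, it remains open whether any other ring at this place could give a lower number than compound 1, for instance one carrying a primary amine, a methoxy group or a carboxylic acid. Nothing available gives a reason for the differences among these three numbers.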